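Trimming the chain of compound 2

The compounds below may be only part of what the source reports. "The series", "measured", "known", "first", "only" and "open" are said of these compounds alone.

For the measured compounds named here, in a functional assay on HeLa cells (Homo sapiens) for antiproliferative activity, read by sulforhodamine B assay, with a stated time of 48 h (on this read-out higher numbers stand for weaker inhibition of growth and lower numbers for stronger inhibition of growth), compound 2 `CCCCCCc1cn(CCCN2C(=O)COc3ccccc32)nn1` gives 100 nM as the only numerical value so far. Compound 1 `COc1ccc2cc(-c3cn(CCCN4C(=O)COc5ccccc54)nn3)ccc2c1` stands at > 100000 nM and this is a limit of the assay. Compound 3 `CCCCc1cn(CCCN2C(=O)COc3ccccc32)nn1` differs from compound 2 by hydrogen in place of ethyl on a saturated chain carbon, four bonds along the chain from an aromatic carbon with hydrogen in place of ethyl on a saturated chain carbon, four bonds along the chain from an aromatic carbon. Going by the values given here, no measured step gauges this change. In this assay weaker growth inhibition beyond the scatter is expected, with an estimated 6.0-fold higher number from compound 2 to compound 3 (0.78 log units; beyond the scatter) as the change. For compound 3 the expected value is 600 nM within an estimated range of 100 nM to 10000 nM for now.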

Compound 3, concentration for 50% growth inhibition: 1020 nM
Compound 3: the middle estimate sits 1.7-fold (0.23 log units) below what was measured; low and high end bracket the measured number.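

In this assay, hydrogen in place of ethyl on a saturated chain carbon, four bonds along the chain from an aromatic carbon, gives a 10-fold higher number from compound 2 to compound 3 (1.01 log units; beyond the scatter), a large step beyond the scatter. For the compounds shown here, this is the first measured step at this position, and it shows that growth inhibition in this pair depends on chain length, with the hexyl chain stronger than the butyl chain.

Going by these compounds, whether a longer chain such as octyl, or a terminal amine or carboxylic acid on the chain, would hold or shift the value stays open. Nothing measured here accounts for the size of the step.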